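The source may hold more compounds than are shown below. What is called first, only, known or untested is meant among the compounds shown, and "the series" means these compounds.

Measured so far in a functional assay on MCF7 cells (Homo sapiens) for antiproliferative activity, read by MTT assay, with a stated time of 48 h; on this read-out lower numbers stand for stronger inhibition and higher numbers for weaker inhibition:
compound 1 `COc1ccc(-c2c(Nc3cc(OC)c(OC)c(OC)c3)c3ccccc3oc2=O)cc1` gives 82300 nM
compound 2 `COc1ccc(-c2c(Nc3cccc(C(F)(F)F)c3)c3ccc(OC)cc3oc2=O)cc1` gives 36200 nM

Compound 1 holds the higher of the two numbers, and compound 2 at 36200 nM lies lower by more than the usual scatter. The two compounds differ in more than one place, so their values isolate no single structural change.

The next compound is compound 3 `COc1ccc(-c2c(Nc3cc(OC)c(OC)c(OC)c3)c3ccc(O)cc3oc2=O)cc1`, not yet measured. It keeps the core of compound 1 and differs from it by one change, (hydroxy in place of hydrogen on an aromatic carbon), with hydroxy in place of hydrogen on an aromatic carbon. Among the measured compounds shown here, no measured pair shows this change, so the expectation remains loose. With compound 1 at 82300 nM, the higher of the two numbers, a move toward a lower number seems somewhat more likely than a move upward. The expected result is a small step in this assay, at or near the scatter, and a step beyond it in either direction cannot be excluded. The estimated step is a 1.6-fold lower number from compound 1 to compound 3 (0.22 log units; within the scatter). For compound 3 the expected value is 50000 nM, with an estimated range from 15000 nM to 120000 nM.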

Compound 3, half-maximal inhibitory concentration: 56000 nM
For compound 3 the middle estimate is 1.1-fold (0.05 log units) below the measured one, and the stated range covers the measured number.
By their numbers in this assay, from the lowest: compounds 2, 3 and 1 (each within the scatter of the next, the first and the last beyond it).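

In this assay, the series now has its first comparison that isolates a single change: hydroxy in place of hydrogen on an aromatic carbon of the fused two-ring part, para to a fused ring and meta to a fused ring, gives a 1.5-fold lower number from compound 1 to compound 3 (0.17 log units; within the scatter). Among the compounds shown here, at this position, then, adding one hydroxy to the core of compound 1 does not separate compound 3 from compound 1 by more than the usual scatter, so this aromatic carbon accepts the group without a clear change in the read-out, and the single step gives no sign of a trend in either direction. No supporting measurement bears on this result, and the size of the step stays unexplained.

Going by these compounds, it remains open whether a group such as an amine or a carboxylic acid on the same aromatic carbon would move the value beyond the scatter, where the hydroxy does not. On these data alone, it is also open whether hydroxy at this position gives a step of similar size on a compound carrying the trifluoromethyl substituent of compound 2 rather than the three methoxy groups of compound 1.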